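Swapping a phenoxy for a methoxy on a thiourea scaffold

The source may report more compounds than this note shows. Statements on the series, on what has been measured and on what is new or still open speak of the compounds shown alone.

Of the compounds shown here, three from this series have been measured so far in a functional assay on CAKI-1 cells (Homo sapiens) for cytotoxicity, read by sulforhodamine B assay, with a stated time of 48 h; a higher number here means a weaker inhibitor of growth, a lower number a stronger inhibitor of growth. Compound 1 `CC1=C(C(=O)Nc2ccc(F)c(Cl)c2)C(c2cccc(O)c2)NC(=S)N1` gives 50100 nM. Compound 2 `CC1=C(C(=O)Nc2ccc(Cl)c(Cl)c2)C(c2cccc(Oc3ccccc3)c2)NC(=S)N1` gives 8510 nM, and compound 3 `CC1=C(C(=O)Nc2ccc(F)c(Cl)c2)C(c2cccc(Oc3ccccc3)c2)NC(=O)N1` gives 10000 nM. Among these three numbers compound 2 has the lowest, but its nearest neighbour, compound 3, sits within the usual scatter of it, so the two cannot be told apart; only compound 1 stands clearly higher, beyond the scatter.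

The next compound, compound 4 `COc1cccc(C2NC(=S)NC(C)=C2C(=O)Nc2ccc(Cl)c(Cl)c2)c1`, keeps the shared core of compound 2 and differs from it in one place: methyl in place of phenyl on an oxygen on an aromatic ring. Within the data shown here, no measured pair in this set shows the effect of exactly this change, so the expectation rests on general experience with small changes of this kind. A step of modest size, toward a somewhat higher number, seems most likely, although a result within the scatter would not be surprising. Compound 4 is therefore expected to give about 20000 nM in this assay, with a plausible range from 8000 nM to 50000 nM. This estimate means a step of a 2.4-fold higher number from compound 2 to compound 4 (0.37 log units; beyond the scatter) that is expected to be small.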

Compound 4, concentration for 50% growth inhibition: 17800 nM
For compound 4 the middle estimate is 1.1-fold (0.05 log units) above the measured one; the range from low to high includes it.
By their numbers in this assay, from the lowest: compounds 2, 3 and 4 (each within the scatter of the next, the first and the last beyond it); then compound 1.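

Among these compounds, this pair gives the first direct reading of the group on this oxygen: with the rest of compound 2 held fixed, going from phenoxy to methoxy gives a 2.1-fold higher number from compound 2 to compound 4 (0.32 log units; beyond the scatter) in this assay and counts as a modest change. The outer phenyl, an aromatic ring of six carbons, gives way to a single methyl carbon, and the read-out shifts only modestly, so at this place in this pair the full ring is not needed for a growth-inhibition value in the same general range. Nothing available bears on why the step has this size, so the result stays an observation without an explanation.

Only the two ends of a possible range of groups on this oxygen are shown here, so an ethoxy, a benzyloxy or a longer chain such as butoxy would be needed to tell whether the number changes gradually between methyl and phenyl or in some less regular way. A single pair also leaves open whether the same swap would give a step of similar size on the core of compound 3, which differs from compound 2 in more than one place.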